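Dropping One Chloro from a Dichlorophenyl Ether

This account rests on a few compounds, and the source may have more. Where it says the series, first, only, none or still open, it means among the compounds named here.

Compound 1 `NC1=NC2(CCSCC2)N(OCCCOc2ccc(Br)cc2)C(N)=N1`: "not determined" (no result reported)
Compound 2 `NC1=NC2(CCOCC2)N(OCCCOc2cccc(Cl)c2Cl)C(N)=N1`: 89.8%
Compound 3 `NC1=NC2(CCSCC2)N(OCCCOc2cccc(Cl)c2Cl)C(N)=N1`: 89.8%

In an assay on isolated protein for inhibition of Dihydrofolate reductase (Homo sapiens), read by spectrophotometry, using NADPH, with stated times of 5 s and 6 min, tested at 50 uM (on this read-out higher numbers stand for a stronger effect at the one concentration tested and lower numbers for a weaker effect), compound 2 gives 89.8%, and compound 3 gives 89.8%, so the two stand level at the digits reported, within the scatter of each other. Compound 1 carries no number in this assay, so it offers no comparison. Among the measured compounds shown here, no step between measured compounds is available to anchor the move to compound 4 `NC1=NC2(CCOCC2)N(OCCCOc2cccc(Cl)c2)C(N)=N1`, which differs from compound 2 by hydrogen in place of chloro on an aromatic carbon. The step from compound 2 to compound 4 is expected to be a modest fall, most likely at or just beyond the scatter, with a number 11.8 percentage points lower from compound 2 to compound 4 (beyond the scatter); a result within the scatter would also not surprise. Compound 4 is therefore estimated at 78%, with a range from 58% to 92%, resting on compound 2 at 89.8% as the only reference point.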

Compound 4, a percentage reported as inhibition, at one concentration (the size of the read-out at that concentration, not a potency): 85.8%
The estimate for compound 4 lay 7.8 percentage points below the measured number, within the range that was stated.
By their numbers in this assay, from the lowest: compounds 4, 2 and 3 (each within the scatter of the next).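

In this assay, hydrogen in place of chloro gives a number 4 percentage points lower from compound 2 to compound 4 (within the scatter), so at this one concentration the read-out does not separate the 2,3-dichlorophenyl ether from the 3-chlorophenyl ether. The earlier compounds shown here with a reported number both carried the 2,3-dichlorophenyl group, and so they could say nothing about this aromatic carbon, ortho to a chloro group, without its own chloro. No supporting measurement is available to explain this result.

From the compounds shown here alone, a single-concentration read-out is not a potency, so it remains open whether compound 2 and compound 4 would differ across a range of concentrations. The compounds shown also do not tell whether a methoxy group, an amine or a nitrile on this aromatic carbon would read like chloro or hydrogen, or what happens if the remaining chloro is replaced by hydrogen.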